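The source may report more compounds than this note shows. Statements on the series, on what has been measured and on what is new or still open speak of the compounds shown alone.

Of the compounds shown here, three have been measured in an assay on Sf9 cells for inhibition of 1-acyl-sn-glycerol-3-phosphate acyltransferase beta (Homo sapiens); a lower number here means a stronger inhibitor, a higher number a weaker inhibitor. Compound 1 `CCOc1ccc(Br)cc1-c1cc(Nc2ccc(C#N)cc2)nc(N)n1` gives 17 nM, compound 2 `CCOc1ccc(Br)cc1-c1cc(Nc2ccc(/C(C)=N\O)cc2)nc(N)n1` gives 84 nM, and compound 3 `Cc1ccc(F)cc1-c1cc(Nc2ccc(Cl)cc2)nc(N)n1` gives 150 nM, the highest number of the three, though its gap to compound 2 lies within the scatter. Among the measured compounds shown here, the only step between compounds differing in a single place, a 4.9-fold higher number from compound 1 to compound 2 (0.69 log units; beyond the scatter), concerns a group on the other ring and does not bear on the change considered here. Compound 4 `Cc1ccc(Br)cc1-c1cc(Nc2ccc(Cl)cc2)nc(N)n1` differs from compound 3 by bromo in place of fluoro on an aromatic carbon. Compounds 1 and 2 both carry bromo at that place, but they differ from compound 3 elsewhere too, so nothing can be read from them about this change alone. A step no larger than the scatter is therefore expected, a 1.4-fold lower number from compound 3 to compound 4 (0.13 log units; within the scatter). Compound 4 is estimated at 110 nM, within 40 nM to 300 nM.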

Compound 4, half-maximal inhibitory concentration: 31 nM
Beside the measured number, compound 4's estimate is 3.5-fold (0.55 log units) above it, and the stated range ends above it.
By their numbers in this assay, from the lowest: compounds 1 and 4 (each within the scatter of the next); then compounds 2 and 3 (each within the scatter of the next).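

Among the compounds shown here, at this place, para to a methyl group, bromo in place of fluoro gives a 4.8-fold lower number from compound 3 to compound 4 (0.68 log units; beyond the scatter) in this assay, the first single-place evidence that the group here matters. The change counts as one heavy atom for one, with no hydrogen-bond donors or acceptors on either side, yet the step lies beyond the scatter. No measurement shown here explains this step. On these data alone, whether iodo or an amine at this place would give a lower or higher number remains open. So does whether the same exchange gives a similar step with ethoxy in place of the methyl group.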